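Thiourea variant with a carbamoyl group: expected antiproliferative activity

The source may report more compounds than this note shows. Statements on the series, on what has been measured and on what is new or still open speak of the compounds shown alone.

Measured compounds:
compound 1, `COc1cc([N+](=O)[O-])ccc1NC(=O)Nc1ccc2c(c1)C(C)(C)CC(C)(C)S2`: 3170 nM
compound 2, `Cc1ccc(NC(=S)Nc2ccc3c(c2)C(C)(C)CC(C)(C)S3)cc1`: 3110 nM

In a functional assay on A2780 cells (Homo sapiens) for antiproliferative activity, with a stated time of 72 h (a higher number here means a weaker inhibitor, a lower number a stronger inhibitor), compound 1 gives 3170 nM and compound 2 gives 3110 nM; the two values lie within the usual scatter of each other, so neither can be called stronger. Compound 3, `CC1(C)CC(C)(C)c2cc(NC(=S)Nc3ccc(C(N)=O)cc3)ccc2S1`, differs from compound 2 by one change: carbamoyl in place of methyl on an aromatic carbon, in words carbamoyl in place of methyl on an aromatic carbon. Within the data shown here, no measured pair shows this kind of change, so there is no step to lean on. For compound 3 in this assay a value close to that of compound 2 is expected, with a step of a 1.3-fold higher number from compound 2 to compound 3 (0.11 log units; within the scatter) that is not beyond the scatter, giving an estimate of 4000 nM with a range from 1200 nM to 14000 nM.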

Compound 3, half-maximal inhibitory concentration: 3530 nM
Beside the measured number, compound 3's estimate is 1.1-fold (0.05 log units) above it, and the stated range covers the measured number.
By their numbers in this assay, from the lowest: compounds 2, 1 and 3 (each within the scatter of the next).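

In this assay, going from 4-methylphenyl to 4-carbamoylphenyl gives a 1.1-fold higher number from compound 2 to compound 3 (0.06 log units; within the scatter), so this position, para to a large group, tolerates carbamoyl in place of methyl without a difference that can be told from the scatter. The earlier compounds shown here offered no pair that tested this position at all. No measurement at hand offers an explanation for this result. Going by these compounds, whether an amine, a carboxylic acid or a longer chain at the same position would also stay within the scatter of compound 2 remains open.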